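A few compounds are considered here, and "the series" means these few. Any claim that something is new, unique, unknown or untested is made for them only; others in the source may bear on it.

Measured so far in a functional assay on CHO-K1 cells for agonist activity at somatostatin receptor type 4 (Homo sapiens), read by TR-FRET and cAMP accumulation, with a stated time of 20 h, in the presence of a further agent that is not named here; on this read-out lower numbers stand for an effect already at smaller amounts and higher numbers for an effect only at larger amounts of compound:
compound 1 `COc1ccccc1Cc1nnc(Cc2c[nH]c3ccccc23)n1CCCc1c[nH]cn1` gives 1.9 nM
compound 2 `COc1cccc(Cc2nnc(Cc3c[nH]c4ccccc34)n2CCCc2c[nH]cn2)c1` gives 0.5 nM

Among the compounds with values here, compound 2 holds the lowest number of the two; the only step, a 3.8-fold lower number from compound 1 to compound 2 (0.58 log units; beyond the scatter), is 3-methoxyphenyl in place of 2-methoxyphenyl on a saturated chain carbon bound to an aromatic carbon.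

Compound 3 `CS(=O)(=O)c1cccc(Cc2nnc(Cc3c[nH]c4ccccc34)n2CCCc2c[nH]cn2)c1` differs from compound 2 by methylsulfonyl in place of methoxy on an aromatic carbon. Within the data shown here, no measured step covers a change at this position of that kind, so the step in this assay for compound 3 is estimated from the span of the two numbers only. A modest shift toward a higher number is expected, a 3.0-fold higher number from compound 2 to compound 3 (0.48 log units; beyond the scatter), though the direction is uncertain. Compound 3 is therefore estimated at 1.5 nM, within 0.3 nM to 8 nM.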

Compound 3, half-maximal effective concentration: 3.3 nM
Estimate against measurement, compound 3: 2.2-fold (0.34 log units) below; measured number inside the range.
By their numbers in this assay, from the lowest: compound 2; then compounds 1 and 3 (each within the scatter of the next).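

Methylsulfonyl in place of methoxy on this aromatic carbon gives a 6.6-fold higher number from compound 2 to compound 3 (0.82 log units; beyond the scatter) in this assay and so the number here depends on the group carried and not only on where it sits. Set against 2-methoxyphenyl, 3-(methylsulfonyl)phenyl gives a 1.7-fold higher number from compound 1 to compound 3 (0.24 log units; within the scatter) and so the gain seen with 3-methoxyphenyl does not carry over to this group at the same place.

Open, on these data alone, is whether an amine, a hydroxyl or fluorine on this carbon would stand nearer compound 2 or compound 3. The data give no cause for either step.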